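The source may report more compounds than this note shows. Statements on the series, on what has been measured and on what is new or still open speak of the compounds shown alone.

Compound 1 `CCn1c(-c2ccccc2)nc2c(NC3CCOC3)ncnc21` gives 10 nM in an assay on CHO cells for displacement of a labelled ligand from adenosine receptor A1 (Homo sapiens), read by scintillation counting, with a stated time of 3 h; on this read-out lower numbers stand for stronger inhibition and higher numbers for weaker inhibition.
Compound 2 `Cn1c(-c2ccc(C(=O)O)cc2)nc2c(NC3CCCC3)ncnc21` gives 54000 nM in this assay.
Compound 3 `Cc1ccc(-c2nc3c(NC4CCCC4)ncnc3n2C)cc1` gives 8 nM in this assay.

Compound 3 gives the lowest of the three numbers in this assay, though compound 1 lies within the scatter of it; compound 2 stands far above both. Within the data shown here, the only measured step, a 6800-fold lower number from compound 2 to compound 3 (3.83 log units; beyond the scatter), concerns a different exchange on the same phenyl ring and so does not speak directly to the change at hand. Compound 4 `Cc1cccc(-c2nc3c(NC4CCCC4)ncnc3n2C)c1` differs from compound 3 by 3-methylphenyl in place of 4-methylphenyl on an aromatic carbon. Among the measured compounds shown here, no measured pair bears on moving the methyl around the ring, so the expectation rests on compound 3 alone, with a step of a 2.5-fold higher number from compound 3 to compound 4 (0.40 log units; beyond the scatter) expected to stay close to the scatter. Compound 4 is therefore estimated at 20 nM in this assay, with a range from 6 nM to 70 nM.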

Compound 4, inhibition constant: 6.2 nM
Compound 4: the middle estimate sits 3.2-fold (0.51 log units) above what was measured; the measured number falls inside the stated range.
By their numbers in this assay, from the lowest: compounds 4, 3 and 1 (each within the scatter of the next); then compound 2.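

The step of a 1.3-fold lower number from compound 3 to compound 4 (0.11 log units; within the scatter) in this assay shows that, on this phenyl ring, 3-methylphenyl and 4-methylphenyl cannot be told apart by this read-out. The earlier step showed only that exchanging carboxy for methyl matters greatly, not that the place of the methyl on the ring matters little. Nothing at hand gives a reason for this result. On these data alone, whether the same holds for other groups remains open, such as an amine or a methoxy group in place of the methyl. As far as these compounds go, it is also open whether a carboxylic acid would behave differently as 3-carboxyphenyl.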